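Thiophene positional isomers on a dihydropyrimidinone core

A few compounds are considered here, and "the series" means these few. Any claim that something is new, unique, unknown or untested is made for them only; others in the source may bear on it.

Measured so far:
compound 1, `CCOC(=O)C1=C(C)N(C)C(=O)NC1c1cccs1`, 1%
compound 2, `CCOC(=O)C1=C(C)N(C)C(=O)NC1c1ccsc1`, 32%
compound 3, `CCSC(=O)C1=C(C)NC(=O)NC1c1cccs1`, 6%

In an assay on membranes from CHO cells for displacement of a labelled ligand from adenosine receptor A1 (Homo sapiens), read by scintillation counting, with a stated time of 60 min, tested at 1 uM (a higher number here means more inhibition at the concentration tested (going by the name of the read-out), a lower number less inhibition), compound 1 gives 1% and compound 2 gives 32%. The change between them is thiophen-3-yl in place of thiophen-2-yl on a saturated ring carbon, and the step was a number 31 percentage points higher from compound 1 to compound 2 (beyond the scatter). Compound 3 gives 6% in this assay; the difference between the cores of compound 1 and compound 3 is not broken down here.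

Compound 4, `CCSC(=O)C1=C(C)NC(=O)NC1c1ccsc1`, is not yet measured. It carries the same kind of change as compound 2: thiophen-3-yl in place of thiophen-2-yl on a saturated ring carbon. The surroundings differ in that the saturated ring carbon here is next to the ring atom that bears a (ethylsulfanyl)carbonyl group rather than an ethoxycarbonyl group, and no third ring bond to a methyl-bearing atom is present. Because a number 31 percentage points higher from compound 1 to compound 2 (beyond the scatter) was large, an upward step a number 20 percentage points higher from compound 3 to compound 4 (beyond the scatter) is expected, though with one precedent only. Compound 4 is estimated at 26%, between 8% and 48%.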

Compound 4, a percentage reported as inhibition, at one concentration (the size of the read-out at that concentration, not a potency): 11%
Compound 4: the middle estimate sits 15 percentage points above what was measured; the measured number falls inside the stated range.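

In this assay, thiophen-3-yl in place of thiophen-2-yl on the saturated ring carbon gives a number 5 percentage points higher from compound 3 to compound 4 (within the scatter) on the core of compound 3. The change therefore does not carry over at the same size from the core of compound 1 to the core of compound 3: the same change on two cores in this assay, a number 31 percentage points higher (beyond the scatter) from compound 1 to compound 2 and a number 5 percentage points higher (within the scatter) from compound 3 to compound 4, 26 percentage points apart, beyond the scatter of two such steps. This shows that the step depends on the core in these two pairs, but not which difference between the cores goes with the gap, and two pairs tested at one concentration set no rule for the series.

Open, on these data alone, is how the change behaves on a core that differs from the core of compound 1 in one place only. Also open, as far as these compounds go, is whether a phenyl group on the saturated ring carbon, or a carboxylic acid in place of the ester or thioester group, would read differently.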